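Moving the pyridine nitrogen: compound 2 to compound 3

The source may report more compounds than this note shows. Statements on the series, on what has been measured and on what is new or still open speak of the compounds shown alone.

The series rests on a shared core, seen in compound 1 `O=C1NC(=O)/C(=C/c2ccc(OCCSc3nnc(Cc4ccccc4)o3)cc2)S1` and compound 2 `O=C1NC(=O)/C(=C/c2ccc(OCCSc3nnc(-c4cccnc4)o3)cc2)S1`. In a functional assay on the whole organism (strain Wistar) with Rattus norvegicus as the target, with a stated time of 15 days, at a dose of 3 mg/kg by the oral route (on this read-out lower numbers stand for a weaker effect and higher numbers for a stronger effect at the one dose given), compound 1 gives 18.5%, and compound 2 gives 40.7%, the higher of the two numbers, the step being a number 22.2 percentage points higher from compound 1 to compound 2 (beyond the scatter). Compound 3 `O=C1NC(=O)/C(=C/c2ccc(OCCSc3nnc(-c4ccncc4)o3)cc2)S1` differs from compound 2 by pyridin-4-yl in place of pyridin-3-yl on an aromatic carbon. Going by the values given here, no measured step pairs pyridin-3-yl against pyridin-4-yl; the one measured step concerns benzyl and therefore offers no direct guide. Compound 3 is expected to show a step of a number 0.7 percentage points lower from compound 2 to compound 3 (within the scatter), so its activity is estimated at 40%, within 20% to 60%.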

Compound 3, a percentage reported as activity, at one dose (the size of the read-out at that dose, not a potency): 40.2%
Compound 3: the middle estimate sits 0.2 percentage points below what was measured; low and high end bracket the measured number.
By their numbers in this assay, from the lowest: compound 1; then compounds 3 and 2 (each within the scatter of the next).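

In this assay, pyridin-4-yl in place of pyridin-3-yl gives a number 0.5 percentage points lower from compound 2 to compound 3 (within the scatter), so the two pyridine groups are not told apart at this position. Pyridin-4-yl in place of benzyl gives a number 21.7 percentage points higher from compound 1 to compound 3 (beyond the scatter), which shows that the step away from benzyl is not confined to pyridin-3-yl. Nothing available explains these results.

The compounds shown leave open whether the step from benzyl would also appear with a plain phenyl group on the same carbon. On these data alone, how pyridin-2-yl would read there also remains open.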